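Adding a hydroxy to an aryl dienone in a phenol series

This account rests on a few compounds, and the source may have more. Where it says the series, first, only, none or still open, it means among the compounds named here.

Compound 1 `COc1ccc(/C=C/C=C/C(=O)c2ccccc2O)cc1OC` was tested in an in vitro assay on cells for inhibition of Amine oxidase [flavin-containing] A (Homo sapiens), read by Amplex Red, with a stated time of 15 min, tested at 100 uM (a higher number here means more inhibition at the concentration tested (going by the name of the read-out), a lower number less inhibition), where compound 1 gives 40%. Within the data shown here, this is the only numerical value available for this assay: a second entry, compound 2 `O=C(/C=C(O)/C=C/c1ccc(Cl)cc1)c1ccccc1O`, is recorded in this assay as "not active" (no number reported), with no number attached. Among the measured compounds shown here, compound 1 therefore stands alone as the reference point, and no step between measured compounds is available to guide expectations.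

Compound 3 `COc1ccc(/C=C/C(O)=C/C(=O)c2ccccc2O)cc1OC` has not yet been measured in this assay. It differs from compound 1 by hydroxy in place of hydrogen on a double-bonded chain carbon bound to two double-bonded chain carbons. Since compound 2 shows "not active" (no number reported) in this assay, a downward step is considered more likely than an upward one. The step from compound 1 to compound 3 is expected to be a number 20 percentage points lower from compound 1 to compound 3 (beyond the scatter), a loss beyond the usual scatter. Compound 3 is estimated to give 20% in this assay, within a range from 5% to 40%.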

Compound 3, a percentage reported as inhibition, at one concentration (the size of the read-out at that concentration, not a potency): "not active" (no number reported)
The entry for compound 3 holds no number; there is nothing to compare the estimate with.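

Compound 3 is recorded in this assay without a number, so no step can be read from compound 1, which gives 40%, to compound 3. The compounds shown leave open how large any change with the hydroxy is. No measurement shown bears on this result.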